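Working notes on a pyridinylmethanol series: clearance

The source may hold more compounds than are shown below. What is called first, only, known or untested is meant among the compounds shown, and "the series" means these compounds.

Three compounds have numbers in an ADME assay on liver for metabolic stability, with Liver microsome (Rattus norvegicus) as the target, read by LC-MS, using microsomes, with a stated time of 5 h; on this read-out lower numbers stand for slow clearance and higher numbers for fast clearance. Compound 1 `C[C@]1(O)C[C@](c2cc(C(F)(F)F)ccn2)([C@H](O)c2ccccn2)C1` gives 100 mL/min/kg, the lowest of the three. Compound 3 `O[C@@]1(c2ccccn2)CC[C@@H](c2ccc(C(F)(F)F)cc2)C1` gives 2520 mL/min/kg and is the nearest to compound 1, a gap beyond the scatter. Compound 2 `O[C@H](c1ccccn1)[C@@]1(c2ccc(Cl)c(Cl)c2)CCCO1` gives 2980 mL/min/kg and is the furthest from compound 1, also beyond the scatter. Compound 1 therefore stands alone at the slow-clearance end of what has been measured.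

Compound 4 `O[C@H](c1ccccn1)[C@]1(c2cc(C(F)(F)F)ccn2)C[C@H](O)C1` has not been measured. It differs from compound 1 in one place: hydrogen in place of methyl on a saturated ring carbon. Going by the values given here, no pair of measured compounds differs by a change of this kind, so nothing measured shows its size. A methyl is a small change against the wide spread seen between compound 1 and the other two, and the expected step in this assay is small, with no direction favoured beyond the scatter. The step that this expectation implies is a 1.3-fold higher number from compound 1 to compound 4 (0.11 log units; within the scatter). Compound 4 is estimated at 130 mL/min/kg, with a range from 45 mL/min/kg to 350 mL/min/kg.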

Compound 4, clearance: 50 mL/min/kg
Estimate against measurement, compound 4: 2.6-fold (0.41 log units) above; the range from low to high includes it.
By their numbers in this assay, from the lowest: compounds 4 and 1 (each within the scatter of the next); then compounds 3 and 2 (each within the scatter of the next).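

In this assay, going by these compounds alone, hydrogen in place of methyl on a saturated ring carbon of the four-membered ring gives a 2.0-fold lower number from compound 1 to compound 4 (0.30 log units; within the scatter), the first direct reading of a change at this position. The methyl is therefore not needed to keep clearance in the range of compound 1, and this ring carbon accepts its removal without a step beyond the scatter. No measurement shown accounts for the size of this step.

This single pair leaves open whether the position would accept anything larger than methyl, such as an ethyl group, or a group of another kind, such as an amine or a carboxylic acid. It also leaves open which structural features separate compound 1 and compound 4 from compound 2 and compound 3, which differ from them in more than one place.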